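Swapping the Ring at the Chain End of Compound 3

This account rests on a few compounds, and the source may have more. Where it says the series, first, only, none or still open, it means among the compounds named here.

Compound 1, `O=C(CO[N+](=O)[O-])Nc1ccc(C(=O)/C=C/c2ccc(Cl)cc2)cc1`, gives 67% in a functional assay on the whole organism (strain albino) for inhibition, with Rattus norvegicus as the target, read by paw edema, with stated times of 30 min and 4 h, at a dose of 100 mg/kg by the oral route; on this read-out lower numbers stand for less inhibition and higher numbers for more inhibition at the one dose given (going by the name of the read-out).
Compound 2, `O=C(CO[N+](=O)[O-])Nc1ccc(C(=O)/C=C/c2ccco2)cc1`, gives 40% in this assay.
Compound 3, `C/C(=N/O)c1ccc(OCC(=O)Nc2ccc(C(=O)/C=C/c3ccc(Cl)cc3)cc2)cc1`, gives 55% in this assay.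

Compound 3 stands second of the three, with a number 12 percentage points lower from compound 1 to compound 3 (beyond the scatter) and compound 2 lower still. Compound 4, `C/C(=N/O)c1ccc(OCC(=O)Nc2ccc(C(=O)/C=C/c3ccco3)cc2)cc1`, differs from compound 3 in one place: furan-2-yl in place of 4-chlorophenyl on a double-bonded chain carbon bound to a double-bonded chain carbon. The same exchange has been seen once, on compound 1, where it gave a number 27 percentage points lower from compound 1 to compound 2 (beyond the scatter). For the measured compounds named here, that is the only step bearing on the new pair, so a drop of similar size is expected in this assay, which would place compound 4 below every measured compound. The estimate for compound 4 is 28%, within 15% to 42%, which means an expected a number 27 percentage points lower from compound 3 to compound 4 (beyond the scatter).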

Compound 4, a percentage reported as inhibition, in the whole organism at one dose (the size of the read-out at that dose, not a potency): 48%
Estimate against measurement, compound 4: 20 percentage points below; the measured number lies above the stated range.
By their numbers in this assay, from the lowest: compounds 2, 4 and 3 (each within the scatter of the next, the first and the last beyond it); then compound 1.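

In this assay the exchange of 4-chlorophenyl for furan-2-yl gives a number 7 percentage points lower from compound 3 to compound 4 (within the scatter) and so has no fixed cost at this place on the chain. The size of the step depends on the core that carries it: the same change on two cores in this assay, a number 27 percentage points lower (beyond the scatter) from compound 1 to compound 2 and a number 7 percentage points lower (within the scatter) from compound 3 to compound 4, 20 percentage points apart, beyond the scatter of two such steps. The other exchange, on the oxygen on a saturated carbon, gives a number 8 percentage points higher from compound 2 to compound 4 (within the scatter) and likewise depends on the ring at the chain end: the same change on two cores in this assay, a number 12 percentage points lower (beyond the scatter) from compound 1 to compound 3 and a number 8 percentage points higher (within the scatter) from compound 2 to compound 4, 20 percentage points apart, beyond the scatter of two such steps.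

From the compounds shown here alone, whether an unsubstituted phenyl or a pyridine ring at this place would follow the same dependence stays open. Two rings on two cores support no general rule.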